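Working notes on a side-chain change, compound 2 to compound 3

A few compounds are considered here, and "the series" means these few. Any claim that something is new, unique, unknown or untested is made for them only; others in the source may bear on it.

Measured so far:
compound 1, `CCCCNC(=O)OCC(O)Cn1cc(CN2CCCC(C(=O)OCC)C2)nn1`, gives 24% in an assay on nucleic acid for inhibition of Nucleic Acid, read by fluorescence, tested at 100 uM; a lower number here means less inhibition, a higher number more inhibition at the concentration tested (going by the name of the read-out)
compound 2, `CCCCC(O)Cn1cc(CN2CCCC(C(=O)OCC)C2)nn1`, gives 53% in this assay

Among the measured compounds shown here, compound 2 holds the highest of the two numbers in this assay; its only neighbour is compound 1, and the single measured step, a number 29 percentage points higher from compound 1 to compound 2 (beyond the scatter), came from propyl in place of (butylcarbamoyl)oxy on a saturated chain carbon, two bonds along the chain from an oxygen on a saturated carbon.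

Compound 3, `CCOC(=O)C1CCCN(Cc2cn(CC(O)COCc3ccccc3)nn2)C1`, differs from compound 2 by benzyloxy in place of propyl on a saturated chain carbon, two bonds along the chain from an oxygen on a saturated carbon. For the measured compounds named here, no measured step covers benzyloxy at this place. The step that bears on the same carbon is a number 29 percentage points higher from compound 1 to compound 2 (beyond the scatter), in which the variant carrying an acceptor at that carbon gave the lower number; the entering group here also carries one acceptor, so the expectation is a downward move, a number 13 percentage points lower from compound 2 to compound 3 (beyond the scatter), though of uncertain size. Compound 3 is therefore estimated at 40% in this assay, within 15% to 65%.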

Compound 3, a percentage reported as inhibition, at one concentration (the size of the read-out at that concentration, not a potency): 26%
The estimate for compound 3 lay 14 percentage points above the measured number; the range from low to high includes it.
By their numbers in this assay, from the lowest: compounds 1 and 3 (each within the scatter of the next); then compound 2.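

Benzyloxy in place of propyl on a saturated chain carbon, two bonds along the chain from an oxygen on a saturated carbon, lowers the reading in this assay (a number 27 percentage points lower from compound 2 to compound 3 (beyond the scatter)), so a second group at this carbon, unlike butylcarbamoyl in structure, also falls short of propyl. Benzyl in place of butylcarbamoyl on an oxygen on a saturated carbon cannot be told apart in this read-out (a number 2 percentage points higher from compound 1 to compound 3 (within the scatter)), which means the two oxygen-linked side chains, one with a six-membered aromatic ring and one without, read alike. Nothing measured explains these numbers.

The compounds shown leave open whether the oxygen at this carbon or the size of the entering group goes with the lower readings. Butoxy and phenethyl at the same carbon would separate the two, and a chain longer than propyl without oxygen would show how far the higher reading of compound 2 extends.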